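Methoxy removal across a small cytotoxicity series

The compounds below may be only part of what the source reports. "The series", "measured", "known", "first", "only" and "open" are said of these compounds alone.

Compound 1 `COc1ccc(C(=O)/C=C/c2ccc(OC)c(OC)c2OC)c(O)c1` is the reference point. In an ADME assay on RAW264.7 cells (Mus musculus) for cytotoxicity, read by MTT assay, with a stated time of 24 h, tested at 10 ug/mL (a higher number here means a weaker effect of the compound at the concentration tested, a lower number a stronger effect), compound 1 gives 75.3%. Among the measured compounds shown here, compound 2 `COc1ccc(C(=O)/C=C/c2cccc(OC)c2OC)c(O)c1` carries one change against compound 1, (hydrogen in place of methoxy on an aromatic carbon), and in this assay compound 2 gives 60.3%; the step of a number 15 percentage points lower from compound 1 to compound 2 (beyond the scatter) is the only change in this set for which a measured pair exists.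

Compound 3 `COc1ccc(C(=O)CCc2ccc(OC)c(OC)c2)c(O)c1` has a different core; how the core of compound 3 differs from the core of compound 1 is not broken down here. In this assay compound 3 gives 67.5%, and against compound 1 and compound 2 its value lies within the scatter, so no order is drawn among the three.

Compound 4 `COc1ccc(CCC(=O)c2ccc(OC)cc2O)cc1` is not yet measured. It differs from compound 3 by hydrogen in place of methoxy on an aromatic carbon. For the measured compounds named here, this is the same kind of change as the one from compound 1 to compound 2, but not the same: around the place in compound 2 the site is ortho to a methoxy group, meta to a methoxy group and para to a large group, while in compound 4 the site is ortho to a methoxy group and meta to a large group.

For compound 4 the step of a number 10.5 percentage points lower from compound 3 to compound 4 (beyond the scatter) is expected because the step of a number 15 percentage points lower from compound 1 to compound 2 (beyond the scatter) goes in that direction. A smaller step than that one is expected: the surroundings of the site differ, and the core of compound 3 is not the core of compound 1. Compound 4 is estimated at 57%, with a range from 44% to 70%.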

Compound 4, a percentage reported as activity, at one concentration (the size of the read-out at that concentration, not a potency): 88%
Compound 4: the middle estimate sits 31 percentage points below what was measured, and the stated range ends below it.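

In this assay, replacing methoxy with hydrogen gives a number 20.5 percentage points higher from compound 3 to compound 4 (beyond the scatter), so the direction of the earlier step on the core of compound 1 does not carry over to the core of compound 3. Within this series, the change therefore has no single direction or size that can be transferred from one core to another, and the two measured pairs disagree: the same change on two cores in this assay, a number 15 percentage points lower (beyond the scatter) from compound 1 to compound 2 and a number 20.5 percentage points higher (beyond the scatter) from compound 3 to compound 4, 35.5 percentage points apart, beyond the scatter of two such steps. This does not show what sets the direction, since the two pairs differ both in their cores and in the surroundings of the changed site, and with one pair on each core these two differences cannot be separated, nor can either step be taken as a general rule for its core.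

Still open, as far as these compounds go, is whether the direction follows the core or the site, which a methoxy-to-hydrogen pair with the same surroundings of the site on both cores would help to settle. Also open, from the compounds shown here alone, is how this assay responds when the methoxy group gives way to something other than hydrogen, such as an amine, a carboxylic acid or a longer alkoxy chain, on either core.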